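The source may hold more compounds than are shown below. What is called first, only, known or untested is meant among the compounds shown, and "the series" means these compounds.

Working notes on the series. Of the compounds shown here, three have been measured in an assay on HEK293 cells for agonist activity at transient receptor potential cation channel subfamily M member 8 (Homo sapiens), read by fluorescence and calcium flux, with a stated time of 15 min; a lower number here means that less compound is needed, a higher number that more compound is needed for the effect. Compound 1 `CCN(Cc1cncs1)C(=O)COc1ccc(C)cc1` gives 1100 nM and compound 2 `CCN(Cc1cccs1)C(=O)c1cc2cc(C)ccc2[nH]1` gives 2010 nM. Compound 3 `Cc1ccc(OCC(=O)N(Cc2cccs2)C2CCCCC2)cc1` gives 40000 nM, the highest number of the three; compound 2 stands nearest to it and compound 1 furthest, both gaps lying beyond the scatter. Compound 4 `CCCN(Cc1cccs1)C(=O)COc1ccc(C)cc1` has not yet been measured. It differs from compound 3 at the amide-type nitrogen: propyl in place of cyclohexyl on an amide-type nitrogen. With a short chain rather than a ring on that nitrogen, compound 4 resembles compound 1, which gives 1100 nM in this assay. A large downward step is therefore expected, a 27-fold lower number from compound 3 to compound 4 (1.43 log units; beyond the scatter). Compound 4 is estimated at 1500 nM, with a range from 400 nM to 6000 nM.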

Compound 4, half-maximal effective concentration: 40 nM
The estimate for compound 4 lay 38-fold (1.57 log units) above the measured number; measured number below the stated range.
By their numbers in this assay, from the lowest: compound 4; then compounds 1 and 2 (each within the scatter of the next); then compound 3.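

In this assay the amide-type nitrogen proves highly sensitive to what it carries: propyl in place of cyclohexyl gives a 1000-fold lower number from compound 3 to compound 4 (3.00 log units; beyond the scatter). Within the data shown here, this is the first single change that can be read, as the earlier compounds held no pair differing in one place.

As far as these compounds go, the step swaps a chain for a larger ring, so ring and size cannot be told apart, and how a butyl chain or a cyclopropyl ring would read stays open. Nothing at hand speaks to the cause of the step.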